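Sulfonamide Variation in a Cyanoguanidine Chromanol Series

The source may report more compounds than this note shows. Statements on the series, on what has been measured and on what is new or still open speak of the compounds shown alone.

The measured compounds and their numbers in a functional assay (aorta) with Rattus norvegicus as the target (on this read-out higher numbers stand for weaker inhibition and lower numbers for stronger inhibition), are:

Compound 1 `CC1(C)Oc2ccc(C(=O)Cc3ccccc3)cc2[C@@H](/N=C(\NC#N)Nc2ccc(Cl)cc2)[C@@H]1O`: 6800 nM
Compound 2 `C=C(c1ccccc1)c1ccc2c(c1)[C@@H](/N=C(\NC#N)Nc1ccc(Cl)cc1)[C@H](O)C(C)(C)O2`: 10700 nM
Compound 3 `CCN(CC)S(=O)(=O)c1ccc2c(c1)[C@@H](/N=C(\NC#N)Nc1ccc(Cl)cc1)[C@H](O)C(C)(C)O2`: 1100 nM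

Compound 3 gives the lowest number of the three in this assay. The nearest is compound 1, reached by a 6.2-fold lower number from compound 1 to compound 3 (0.79 log units; beyond the scatter); the furthest is compound 2, reached by a 9.7-fold lower number from compound 2 to compound 3 (0.99 log units; beyond the scatter). Between compound 1 and compound 2 there is a 1.6-fold higher number from compound 1 to compound 2 (0.20 log units; within the scatter).

Compound 4 `CC(C)CN(CC(C)C)S(=O)(=O)c1ccc2c(c1)[C@@H](/N=C(\NC#N)Nc1ccc(Cl)cc1)[C@H](O)C(C)(C)O2` differs from compound 3 only at the sulfonamide nitrogen: diisobutylamino in place of diethylamino on a sulfonyl sulfur. The measured steps all concern exchanges of the whole substituent on the aromatic carbon, not a change of the groups on the sulfonamide nitrogen itself, so none of them bears directly on this step. Compound 4 keeps the diethylsulfamoyl-type feature that set compound 3 apart from compound 1 and compound 2. Among the compounds with values here, with no measured step to guide the size or direction, a change in this assay of the size a 1.4-fold higher number from compound 3 to compound 4 (0.13 log units; within the scatter) is expected, which is no more than the usual scatter. Compound 4 is therefore estimated at 1500 nM in this assay, with a range from 400 nM to 6000 nM.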

Compound 4, half-maximal inhibitory concentration: 9400 nM
Compound 4: the middle estimate sits 6.3-fold (0.80 log units) below what was measured; the measured number lies above the stated range.
By their numbers in this assay, from the lowest: compound 3; then compounds 1, 4 and 2 (each within the scatter of the next).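

In this assay the groups on the sulfonamide nitrogen prove to matter at this position: diisobutylamino in place of diethylamino on a sulfonyl sulfur gives an 8.5-fold higher number from compound 3 to compound 4 (0.93 log units; beyond the scatter) and thus shows that the sulfonyl group alone does not secure the low number of compound 3. The diisobutylsulfamoyl compound also loses the separation from the two compounds without a sulfonamide, with a 1.1-fold lower number from compound 2 to compound 4 (0.06 log units; within the scatter) and a 1.4-fold higher number from compound 1 to compound 4 (0.14 log units; within the scatter) both printed as within the scatter, so the advantage seen earlier over 1-phenylethenyl and benzylcarbonyl belongs here to diethylsulfamoyl and does not extend to diisobutylsulfamoyl. No evidence is available on what lies behind this step, so the data give its size and direction and nothing further.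

The compounds shown carry only diethylamino and diisobutylamino on the sulfonyl sulfur, so they cannot separate the effect of a longer chain from that of a branched one. From the compounds shown here alone, how dimethylamino, a piperidine ring or a morpholine ring would read in this position remains open, as does whether any group on the sulfonamide nitrogen would go lower than diethylamino.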